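Lengthening the hydroxycarbamoyl chain: compound 2 to compound 3

The compounds below may be only part of what the source reports. "The series", "measured", "known", "first", "only" and "open" are said of these compounds alone.

Measured in a functional assay on MC-38 cells (Mus musculus) for antiproliferative activity, read by CCK-8 assay, with a stated time of 48 h; a lower number here means a stronger inhibitor, a higher number a weaker inhibitor:
- compound 1 `O=C(CCCCCCOc1ccc(-c2nnc(-c3ccccc3)s2)cc1)NO`: 14000 nM
- compound 2 `O=C(CCCCOc1cccc(-c2nnc(-c3ccccc3)s2)c1)NO`: 7100 nM

Among the compounds with values here, compound 2, at 7100 nM, stands within the usual scatter of compound 1, at 14000 nM, the only other measured compound. Within the data shown here, these two differ in more than one place, so the series offers no measured single-place step to use as a guide.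

The next compound is compound 3 `O=C(CCCCCOc1cccc(-c2nnc(-c3ccccc3)s2)c1)NO`. The change is (hydroxycarbamoyl)methyl in place of hydroxycarbamoyl on a saturated chain carbon, four bonds along the chain from an oxygen on an aromatic ring.

The expected change in this assay, a 1.3-fold lower number from compound 2 to compound 3 (0.11 log units; within the scatter), is small, with no move beyond the scatter in either direction. For compound 3 the estimated value is 5500 nM, with an expected range of 2000 nM to 14000 nM.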

Compound 3, half-maximal inhibitory concentration: 430 nM
Estimate against measurement, compound 3: 13-fold (1.11 log units) above; measured number outside the range, below it.
By their numbers in this assay, from the lowest: compound 3; then compounds 2 and 1 (each within the scatter of the next).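

The chain bearing the hydroxycarbamoyl end proves sensitive in this assay: (hydroxycarbamoyl)methyl in place of hydroxycarbamoyl, on a saturated chain carbon, four bonds along the chain from an oxygen on an aromatic ring, gives a 17-fold lower number from compound 2 to compound 3 (1.22 log units; beyond the scatter) in this series. Within the data shown here, this is the first single-place reading, and it shows that chain length alone, with the rest of compound 2 unchanged, can move the number well beyond the scatter. Nothing at hand explains the size of this step.

Going by these compounds, whether the number keeps falling, levels off or rises again with a longer chain at this place remains open. Also open, on these data alone, is whether the lower number depends on the hydroxycarbamoyl end itself, which a carboxylic acid or a primary amide in its place would test.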